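A few compounds are considered here, and "the series" means these few. Any claim that something is new, unique, unknown or untested is made for them only; others in the source may bear on it.

Measured compounds:
- compound 1, `Cc1cc(C)c(S(=O)(=O)N[C@@H](CNC(=O)CO[C@@H]2C[C@@H](CNc3ccccn3)N(C(=O)OCc3ccccc3)C2)C(=O)O)c(C)c1`: in an assay on a protein complex for inhibition of integrin alpha-5/beta-1 (Homo sapiens), read by ELISA (a lower number here means a stronger inhibitor, a higher number a weaker inhibitor), compound 1 gives 3.7 nM
- compound 2, `O=C(CO[C@@H]1C[C@@H](CNc2ccccn2)N(C(=O)OCc2ccccc2)C1)NC[C@H](NS(=O)(=O)c1ccccc1)C(=O)O`: compound 2 gives 86 nM
- compound 3, `CC1(C(=O)N[C@@H](CNC(=O)CO[C@@H]2C[C@@H](CNc3ccccn3)N(C(=O)OCc3ccccc3)C2)C(=O)O)CCCCC1`: compound 3 gives 1.7 nM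

Compound 1 stands second highest of the three numbers. Its nearest neighbour is compound 3, with a 2.2-fold lower number from compound 1 to compound 3 (0.34 log units; beyond the scatter); the furthest is compound 2, with a 23-fold higher number from compound 1 to compound 2 (1.37 log units; beyond the scatter). Between the other two, a 51-fold lower number from compound 2 to compound 3 (1.70 log units; beyond the scatter). All three measured steps alter the group on the amine nitrogen of the acid-bearing chain; none alters the ring nitrogen that carries the benzyloxycarbonyl group.

Compound 4 `Cc1cc(C)c(S(=O)(=O)N[C@@H](CNC(=O)CO[C@@H]2C[C@@H](CNc3ccccn3)N(CCCc3ccccc3)C2)C(=O)O)c(C)c1` differs from compound 1 at exactly that ring nitrogen: 3-phenylpropyl in place of benzyloxycarbonyl on an amine nitrogen in a ring. Going by the values given here, no measured step bears on this position, so the numbers so far give neither a direction nor a size for it. The expectation for compound 4 in this assay is therefore wide, centred close to compound 1, with a 2.2-fold higher number from compound 1 to compound 4 (0.33 log units; beyond the scatter) the expected outcome. Compound 4 is estimated at 8 nM, with a range from 2 nM to 40 nM.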

Compound 4, half-maximal inhibitory concentration: 670 nM
Compound 4: the middle estimate sits 84-fold (1.92 log units) below what was measured, outside the stated range (above it).
By their numbers in this assay, from the lowest: compound 3; then compound 1; then compound 2; then compound 4.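

The ring nitrogen that carries benzyloxycarbonyl is a sensitive position in this assay: exchanging that group for 3-phenylpropyl gives a 180-fold higher number from compound 1 to compound 4 (2.26 log units; beyond the scatter), a larger step than the biggest one measured on the amine nitrogen of the acid-bearing chain (a 51-fold lower number from compound 2 to compound 3 (1.70 log units; beyond the scatter)). The exchange keeps the six-membered aromatic ring but loses the double bond outside aromatic rings and the hydrogen-bond acceptors of benzyloxycarbonyl, so a similar number of heavy atoms and an aromatic ring do not by themselves hold the potency. No available data account for the size of this step.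

An amide or a urea on the ring nitrogen would test whether the carbonyl alone matters, apart from the carbamate oxygen. Also open, going by these compounds, is whether 3-phenylpropyl has the same effect with (1-methylcyclohexyl)carbonyl on the amine nitrogen.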